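The source may report more compounds than this note shows. Statements on the series, on what has been measured and on what is new or still open speak of the compounds shown alone.

Compound 1 `O=C(Cc1csc2nc(-c3ccc(Br)cc3)cn12)N/N=C/c1ccccc1`: 63100 nM
Compound 2 `O=C(Cc1csc2nc(-c3ccc(Br)cc3)cn12)N/N=C/c1ccccc1O`: 17400 nM

Among the compounds with values here, in a functional assay on SW-620 cells (Homo sapiens) for inhibition, read by sulforhodamine B assay, with a stated time of 48 h (on this read-out higher numbers stand for weaker inhibition of growth and lower numbers for stronger inhibition of growth), compound 1 gives 63100 nM, the higher of the two numbers so far, so its growth inhibition is the weaker of the pair. Compound 2 gives 17400 nM. The next compound to be considered is compound 3 `O=C(Cc1csc2nc(-c3ccc(Br)cc3)cn12)N/N=C/c1ccc(O)cc1`, which keeps the core of compound 1 and changes only the phenyl, which becomes 4-hydroxyphenyl: hydroxy in place of hydrogen on an aromatic carbon. The hydroxy takes the place of hydrogen on an aromatic carbon, para to a large group.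

Within the data shown here, only one measured step bears on this change: a 3.6-fold lower number from compound 1 to compound 2 (0.56 log units; beyond the scatter). That modest step also puts hydroxy in place of hydrogen on an aromatic carbon, but at a different place on the ring. A single step cannot show how far the effect carries over, so a modest move toward a lower number is expected, possibly a smaller one than that step, and with wide uncertainty. This estimate corresponds to an expected step of a 2.1-fold lower number from compound 1 to compound 3 (0.32 log units; beyond the scatter). For compound 3, the estimated value is 30000 nM, with an expected range of 10000 nM to 80000 nM.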

Compound 3, concentration for total growth inhibition: > 100000 nM
Compound 3: only a limit was reported; the forecaster's own chance of this, stated with the estimate: 15%; middle value at least 3.3-fold (0.52 log units) away from the limit.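

The value of compound 3 in this assay is a limit and not a number: the limit of > 100000 nM in this assay, at which 1 of the 3 values shown sits. Placed para to a large group, hydroxy does not repeat a 3.6-fold lower number from compound 1 to compound 2 (0.56 log units; beyond the scatter); the result is instead an at least 1.5-fold higher number from compound 1 to compound 3 (0.19 log units; that floor lies within the scatter), so the same change does not lower the number at this position, although that floor alone does not set compound 3 apart from compound 1 beyond the scatter. The clearer contrast is between 2-hydroxyphenyl and 4-hydroxyphenyl, with an at least 5.7-fold higher number from compound 2 to compound 3 (0.75 log units; beyond the scatter), which shows that among these three compounds the place of the hydroxy on the ring decides whether the number falls.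

From the compounds shown here alone, it remains open whether this dependence on place belongs to hydroxy alone or would also appear with a methoxy group, an amine or a fluorine at the same ring positions. Going by these compounds, it is also open how far the true value of compound 3 lies beyond its limit, and whether the lower number of the 2-hydroxyphenyl compound would persist if the 4-bromophenyl group on the shared core gave way to a 4-chlorophenyl group.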